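A few compounds are considered here, and "the series" means these few. Any claim that something is new, unique, unknown or untested is made for them only; others in the source may bear on it.

Going by the values given here, compound 1 `CCOC(=O)CN1C(=O)S/C(=C\c2ccc(-c3ccc(Cl)cc3Cl)o2)C1=O` is one of only two compounds measured in a functional assay on K562 cells for agonist activity at integrin alpha-M/beta-2 (Homo sapiens); on this read-out higher numbers stand for an effect only at larger amounts of compound and lower numbers for an effect already at smaller amounts. In this assay compound 1 gives 13600 nM, the lowest of the two numbers. Its nearest neighbour, compound 2 `CCOC(=O)CN1C(=O)S/C(=C\c2ccc(-c3ccc(C)cc3Br)o2)C1=O`, gives 18600 nM, and the step of a 1.4-fold higher number from compound 1 to compound 2 (0.14 log units; within the scatter) means the two cannot be told apart. That step concerns the aryl group on the furan, not the group on the ring nitrogen.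

Compound 3 `O=C1S/C(=C\c2ccc(-c3ccc(Cl)cc3Cl)o2)C(=O)N1c1ccccc1` has not yet been measured. Compared with compound 1, the change is phenyl in place of (ethoxycarbonyl)methyl on an amide-type nitrogen in a ring. Among the compounds with values here, no measured step touches this position, so nothing among the two known values shows whether swapping the ester-bearing chain for a flat aromatic ring on the amide-type nitrogen moves the number at all. The sensible expectation is therefore a step of a 1.0-fold higher number from compound 1 to compound 3 (0.01 log units; within the scatter) that stays within the scatter, with a wide range on either side. Compound 3 is estimated at 14000 nM, expected to fall between 4000 nM and 50000 nM.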

Compound 3, half-maximal effective concentration: > 50000 nM
Compound 3: a limit, no number; the forecaster's own chance of this, stated with the estimate: 20%; at least 3.5-fold (0.55 log units) between middle value and limit.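

The earlier pair differed only in the aryl group on the furan, so the group on the amide-type nitrogen had not yet been tested. Placing phenyl there instead of (ethoxycarbonyl)methyl gives an at least 3.6-fold higher number from compound 1 to compound 3 (0.56 log units; beyond the scatter), which shows that in this assay this position is not indifferent to the group it carries, and that this swap pushes the read-out towards larger amounts of compound. Compound 3 has only a limit and not a number, so the full size of the step remains unknown: the limit of > 50000 nM in this assay, at which 1 of the 3 values shown sits.

This single change removes a chain and brings in a ring, so the compounds shown cannot separate the loss of (ethoxycarbonyl)methyl from the arrival of phenyl. A carboxylic acid on a one-carbon chain, a plain ethyl group or a benzyl group on the same nitrogen would help tell these two apart.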